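Swapping Chlorine for Bromine on an Amide-Linked Ring

The source may report more compounds than this note shows. Statements on the series, on what has been measured and on what is new or still open speak of the compounds shown alone.

Measured compounds:
Compound 1, `CN(C(=O)CCc1ccccc1)c1ccc2[nH]c(-c3n[nH]c4ccccc34)cc2n1`: 4730 nM
Compound 2, `CN(C(=O)c1ccc(Cl)cc1)c1ccc2[nH]c(-c3n[nH]c4ccccc34)cc2n1`: 450 nM

Both numbers come from a functional assay on HL-60 cells (Homo sapiens) for antiproliferative activity, read by MTT assay, with a stated time of 72 h; a higher number here means a weaker inhibitor, a lower number a stronger inhibitor. Compound 2 stands at the lowest of the two numbers; its nearest neighbour is compound 1, and the change between them, a 4-chlorophenyl in place of a phenethyl on the carbonyl carbon, gave an 11-fold lower number from compound 1 to compound 2 (1.02 log units; beyond the scatter). For the measured compounds named here, that is the only measured step available.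

Compound 3, `CN(C(=O)c1ccc(Br)cc1)c1ccc2[nH]c(-c3n[nH]c4ccccc34)cc2n1`, has not yet been measured. It differs from compound 2 in one place: bromo in place of chloro on an aromatic carbon. Going by the values given here, no measured step involves an exchange of one halogen for another. Among the compounds with values here, the single known step, an 11-fold lower number from compound 1 to compound 2 (1.02 log units; beyond the scatter), replaced a flexible chain with a substituted ring, a change of a quite different kind, so it gives little guidance here beyond showing that this position matters. The expectation in this assay is therefore a step of small size, in either direction, most likely within the scatter. Compound 3 is expected to give about 420 nM, with a plausible range from 160 nM to 1100 nM. The expected step is a 1.1-fold lower number from compound 2 to compound 3 (0.03 log units; within the scatter), which lies within the scatter.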

Compound 3, half-maximal inhibitory concentration: 1080 nM
Beside the measured number, compound 3's estimate is 2.6-fold (0.41 log units) below it; the range from low to high includes it.
By their numbers in this assay, from the lowest: compound 2; then compound 3; then compound 1.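

In this assay, for the compounds shown here, the two halogens are not interchangeable at this position: exchanging chloro for bromo on the aromatic carbon para to a large group gives a 2.4-fold higher number from compound 2 to compound 3 (0.38 log units; beyond the scatter) even though only one heavy atom changes. The ring still compares well with the flexible chain, since the step of a 4.4-fold lower number from compound 1 to compound 3 (0.64 log units; beyond the scatter) shows that a 4-bromophenyl on the carbonyl carbon also beats phenethyl, so this advantage is not confined to the 4-chlorophenyl compound, although it is smaller here. No measurement is available to explain why the bromo compound gives the higher number.

Going by these compounds, two halogens cannot establish a trend, so it remains open how fluoro, a plain hydrogen, a methoxy group or an amine on the same ring carbon would compare with chloro and bromo. On these data alone, it is also open whether the same exchange would give a similar step with the halogen-bearing ring held further from the carbonyl by a longer chain, or with a different group on the amide nitrogen in place of methyl.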